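This account rests on a few compounds, and the source may have more. Where it says the series, first, only, none or still open, it means among the compounds named here.

Compound 1 `COc1cc(SC)nc(NC(=S)NC(=O)c2c(-c3ccc(Cl)cc3Cl)noc2C)n1` was tested in a functional assay on the whole organism (strain L.) for inhibition, with Echinochloa crus-galli as the target, with a stated time of 72 h, tested at 10 mg/L (on this read-out lower numbers stand for less inhibition of growth and higher numbers for more inhibition of growth at the one concentration tested), where compound 1 gives 19.3%. That puts compound 1 at the low end of the two numbers at hand, though the gap to compound 2 `Cc1onc(-c2ccc(Cl)cc2Cl)c1C(=O)/N=c1/nc2nc(Cl)cc(C)n2s1`, which gives 25.8% in this assay, lies within the scatter. Compound 3 `Cc1cc(C)nc(NC(=S)NC(=O)c2c(-c3ccc(Cl)cc3Cl)noc2C)n1` is not yet measured; it differs from compound 1 by 4,6-dimethylpyrimidin-2-yl in place of 4-methoxy-6-(methylsulfanyl)pyrimidin-2-yl on an amide-type nitrogen. Among the measured compounds shown here, no measured pair shows such a change, so no size of step can be drawn from the data; in this assay the expected step is none beyond the scatter, a number 1.7 percentage points higher from compound 1 to compound 3 (within the scatter). Compound 3 is accordingly estimated at 21% in this assay, within 5% to 42%.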

Compound 3, percent growth inhibition at one concentration: 18.5%
Compound 3: middle estimate off by 2.5 percentage points, on the high side; the range from low to high includes it.
By their numbers in this assay, from the lowest: compounds 3, 1 and 2 (each within the scatter of the next).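

In this assay, putting 4,6-dimethylpyrimidin-2-yl in place of 4-methoxy-6-(methylsulfanyl)pyrimidin-2-yl on an amide-type nitrogen gives a number 0.8 percentage points lower from compound 1 to compound 3 (within the scatter), the first step measured at this position. For this pair, then, exchanging the methoxy and methylsulfanyl groups for methyl groups leaves the read-out within the usual scatter. No measurement shown here bears on this result. The compounds shown leave open whether a different group at this place, such as an amine or a carboxylic acid, would shift growth inhibition beyond the scatter. They also leave open whether this pair would still match at other concentrations.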